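Swapping the Side Chain of Compound 1

The source may hold more compounds than are shown below. What is called first, only, known or untested is meant among the compounds shown, and "the series" means these compounds.

Of the compounds shown here, three have been tested in a functional assay on the whole organism (Tail, strain ICR) with Mus musculus as the target, in the tail flick test, with a stated time of 30 min, at a dose of 25 umol/kg by the oral route; a higher number here means a stronger effect of the compound at the dose given, a lower number a weaker effect. Compound 1, `N=C(N)NCCC[C@H](NC(=O)CN(c1ncnc2c1ncn2C1CCCCO1)C1CC1)C(=O)OCc1ccccc1`, gives 34.3%. Compound 2, `O=C(OCc1ccccc1)[C@@H]1CCCN1C(=O)CN(c1nc(Cl)nc2[nH]cnc12)C1CC1`, gives 33.2%, and compound 3, `CC[C@H](C)[C@H](NC(=O)CN(c1nc(Cl)nc2[nH]cnc12)C1CC1)C(=O)OCc1ccccc1`, gives 41.4%. The number for compound 1 is the second highest of the three, yet its gap to compound 2 and its gap to compound 3 both lie inside the usual scatter of repeated measurements, so on these numbers the three compounds cannot be told apart. Within the data shown here, no pair among them differs in only one place, so no single structural step has yet been tied to a change in the read-out.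

Compound 4, `NC(=O)C[C@H](NC(=O)CN(c1ncnc2c1ncn2C1CCCCO1)C1CC1)C(=O)OCc1ccccc1`, has not been measured. It is compound 1 with one change: a group of 3 heavy atoms (1 carbon, 1 nitrogen, 1 oxygen; no ring) in place of a group of 6 heavy atoms (3 carbon, 3 nitrogen; no ring), on a saturated chain carbon, two bonds along the chain from an amide-type nitrogen and a carbonyl carbon. Among the measured compounds shown here, nothing measured so far shows how such a change moves the read-out in this assay. The step is therefore expected to be a number 1.3 percentage points lower from compound 1 to compound 4 (within the scatter), which is no movement beyond the scatter. Compound 4 is estimated at 33%, within a range from 20% to 46%.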

Compound 4, a percentage reported as activity, at one dose (the size of the read-out at that dose, not a potency): 34.5%
For compound 4 the middle estimate is 1.5 percentage points below the measured one, and the stated range covers the measured number.
By their numbers in this assay, from the lowest: compounds 2, 1, 4 and 3 (each within the scatter of the next).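

In this assay, among these compounds, the first step that changes one place only is a number 0.2 percentage points higher from compound 1 to compound 4 (within the scatter) and so shows no movement. On the saturated chain carbon, carbamoyl can take the place of the group of 6 heavy atoms without a read-out that can be told apart from that of compound 1, so on this core the larger group is not required for the effect seen at this one dose. Nothing measured here explains why the two compounds read alike.

What a carboxylic acid, a simple methyl or a primary amine on a longer chain would do at this carbon stays open, since none of them is among the compounds shown. A single dose also leaves open whether compound 1 and compound 4 would still read alike at other doses.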